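The source may report more compounds than this note shows. Statements on the series, on what has been measured and on what is new or still open speak of the compounds shown alone.

Compound 2 `COc1cc(Cl)cc(-c2nn(-c3cccc(NC(=O)Nc4cc(C(F)(F)F)cc(C(F)(F)F)c4)c3)cc2-c2ccncc2)c1` and compound 1 `O=C(Nc1cccc(-n2cc(-c3ccncc3)c(-c3cc(O)cc(Cl)c3)n2)c1)Nc1ccc(Cl)c(C(F)(F)F)c1` share a core. In a functional assay on MDA-MB-231 cells (Homo sapiens) for inhibition, read by sulforhodamine B assay, with a stated time of 48 h, tested at 0.1 uM (a lower number here means a stronger effect, a higher number a weaker effect of the compound at the concentration tested), compound 1 gives 105%, whereas compound 2 gives 90%, the lower of the two numbers, and its gap to compound 1 lies beyond the scatter. Compound 3 `COc1cc(Cl)cc(-c2nn(-c3cccc(NC(=O)Nc4cccc(C(F)(F)F)c4)c3)cc2-c2ccncc2)c1` differs from compound 2 by hydrogen in place of trifluoromethyl on an aromatic carbon. For the measured compounds named here, no step of this kind has been measured here. In this assay a small shift toward a higher number, or none beyond the scatter, seems most likely. Compound 3 is therefore expected to give about 96%, between 82% and 110%. This amounts to an expected step of a number 6 percentage points higher from compound 2 to compound 3 (within the scatter).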

Compound 3, a percentage reported as activity, at one concentration (the size of the read-out at that concentration, not a potency): 103%
Compound 3: middle estimate off by 7 percentage points, on the low side, and the stated range covers the measured number.
By their numbers in this assay, from the lowest: compound 2; then compounds 3 and 1 (each within the scatter of the next).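

In this assay, hydrogen in place of trifluoromethyl on this aromatic carbon gives a number 13 percentage points higher from compound 2 to compound 3 (beyond the scatter). For the compounds shown here, this is the first change at a single place, and it shows that the trifluoromethyl group at this place, meta to a trifluoromethyl group, is linked to a modest but real difference in the read-out. Nothing measured here explains the step. From the compounds shown here alone, whether an amine, a nitrile or a carboxylic acid on this carbon would give a number nearer that of compound 2 or that of compound 3 remains open.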